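Compound 2 to compound 4: replacing hydroxy with pyridin-2-yl

This account rests on a few compounds, and the source may have more. Where it says the series, first, only, none or still open, it means among the compounds named here.

compound 1 `O=C(O)CCCCC(CCSC(=O)c1ccccc1)SC(=O)c1ccccc1` gives 89.8%
compound 2 `O=C(CCCCC1CCSS1)NO` gives 12.4%
compound 3 `O=C(CCCCC(S)CCS)NO` gives 58%

In a functional assay on KB cells (Homo sapiens) for inhibition, read by MTT assay, with a stated time of 24 h, tested at 100 ug/mL (a lower number here means less inhibition of growth, a higher number more inhibition of growth at the concentration tested), compound 2 stands lowest of the three. Compound 3 lies higher, beyond the scatter, and compound 1 lies furthest away, also beyond the scatter.

The compound to be measured next is compound 4 `O=C(CCCCC1CCSS1)Nc1ccccn1` and the change from compound 2 is pyridin-2-yl in place of hydroxy on an amide-type nitrogen as counted. In words, pyridin-2-yl stands in place of hydroxy on an amide-type nitrogen, and the rest of the structure stays the same.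

Among the compounds with values here, no measured pair in this small series isolates that change, so the data give no direct size for it. Within the data shown here, the only guide is the spread of values. Compound 2 at 12.4% sits near the bottom of the read-out, while compound 3 at 58% and compound 1 at 89.8% show how much higher this series can reach. An upward move is therefore the more likely direction, but the support for it is thin.

The expected move is a number 17.6 percentage points higher from compound 2 to compound 4 (beyond the scatter) as an estimate, which would lie beyond the scatter. For compound 4 the estimated value is 30% with 10% and 60% as the expected lower and upper ends.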

Compound 4, percent growth inhibition at one concentration: 25.1%
The estimate for compound 4 lay 4.9 percentage points above the measured number; low and high end bracket the measured number.
By their numbers in this assay, from the lowest: compound 2; then compound 4; then compound 3; then compound 1.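

In this assay, within the data shown here, the replacement of hydroxy by pyridin-2-yl on an amide-type nitrogen gives the first single-change step: a number 12.7 percentage points higher from compound 2 to compound 4 (beyond the scatter). The position therefore accepts one six-membered aromatic ring with 1 hetero atom in place of a single oxygen-bearing group, and the hydrogen-bond donor of the hydroxy is lost, with no drop in growth inhibition at the concentration tested; the gain is modest, though it lies beyond the usual scatter. No measurement at hand accounts for this step.

The compounds shown leave open whether the gain belongs to the pyridine nitrogen or to any aromatic ring on the amide-type nitrogen, a question that a plain phenyl group or a pyridin-4-yl group at the same place would address. Also open, on these data alone, is whether pyridin-2-yl would give a step of similar direction and size on the core of compound 3, or on a core with a longer chain between the carbonyl and the sulfur-bearing end.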